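Ethylcarbamoyl for ethylsulfamoyl on the biaryl series

The source may hold more compounds than are shown below. What is called first, only, known or untested is meant among the compounds shown, and "the series" means these compounds.

Measured so far:
compound 1 `CCOC(=O)c1cccc(-c2ccc(OCC)c([N+](=O)[O-])c2)c1` — 200000 nM
compound 2 `CCNS(=O)(=O)c1cccc(-c2ccc(OCC)cc2)c1` — 200000 nM

In an assay on COS-7 cells for inhibition of patatin-like phospholipase domain-containing protein 2 (Mus musculus) (on this read-out higher numbers stand for weaker inhibition and lower numbers for stronger inhibition), compound 1 gives 200000 nM and compound 2 gives 200000 nM; compound 2 stands level with compound 1, within the scatter. Compound 3 `CCNC(=O)c1cccc(-c2ccc(OCC)cc2)c1` is not yet measured. It differs from compound 2 by ethylcarbamoyl in place of ethylsulfamoyl on an aromatic carbon. Both measured values sit at the same weak level, so no change beyond the scatter is expected from compound 2 to compound 3. For compound 3 the expected value in this assay is 200000 nM, range 80000 nM to 300000 nM, a step of no change at the digits printed from compound 2 to compound 3 (within the scatter).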

Compound 3, half-maximal inhibitory concentration: 90000 nM
Estimate against measurement, compound 3: 2.2-fold (0.35 log units) above; the range from low to high includes it.
By their numbers in this assay, from the lowest: compound 3; then compounds 1 and 2 (each within the scatter of the next).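

In this assay, within the data shown here, ethylcarbamoyl in place of ethylsulfamoyl on this aromatic carbon gives a 2.2-fold lower number from compound 2 to compound 3 (0.35 log units; beyond the scatter), the first step to lie beyond the scatter. The position therefore responds to a change of group, though only modestly, with the smaller group of the pair giving the lower number. No evidence on hand bears on the reason for this step.

On these data alone, it remains open whether a carboxylic acid at this position would lower the number further. A propyl chain in place of the ethyl on the carbamoyl group is equally untested.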